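Phenyl for Phenoxymethyl on the Acid-Bearing Analogue

The compounds below may be only part of what the source reports. "The series", "measured", "known", "first", "only" and "open" are said of these compounds alone.

Compound 1: `NC(=O)c1cccc(-c2cnc(C(=O)CCc3ccc(-c4ccccc4)cc3)o2)n1`, 1.2 nM
Compound 2: `COC(=O)c1ccc(-c2cnc(C(=O)CCc3ccc(-c4ccccc4)cc3)o2)cn1`, 0.6 nM
Compound 3: `O=C(O)c1ccc(-c2cnc(C(=O)CCc3ccc(COc4ccccc4)cc3)o2)nc1`, 4.6 nM

In an assay for inhibition of Fatty-acid amide hydrolase 1 (Rattus norvegicus) (on this read-out higher numbers stand for weaker inhibition and lower numbers for stronger inhibition), compound 3 gives 4.6 nM, the highest number of the three; compound 1 stands closer to it and compound 2 furthest away, both beyond the scatter. Among the compounds with values here, the only measured step, a 2.0-fold lower number from compound 1 to compound 2 (0.30 log units; within the scatter), concerns the head group and lies within the scatter, so the head group alone does not move the numbers much here.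

Compound 4, `O=C(O)c1ccc(-c2cnc(C(=O)CCc3ccc(-c4ccccc4)cc3)o2)nc1`, differs from compound 3 in one place: phenyl in place of phenoxymethyl on an aromatic carbon. Within the data shown here, no measured pair isolates this change, so the expectation rests on the tail shared by compounds 1 and 2, which both carry the phenyl and give low numbers in this assay. Because compound 1 gives 1.2 nM and compound 2 gives 0.6 nM with that same tail, compound 4 is expected to fall near them. The step of a 3.1-fold lower number from compound 3 to compound 4 (0.49 log units; beyond the scatter) is therefore estimated to run toward stronger inhibition, most likely beyond the scatter. Compound 4 is expected at 1.5 nM, within 0.4 nM to 6 nM.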

Compound 4, inhibition constant: 14 nM
For compound 4 the middle estimate is 9.3-fold (0.97 log units) below the measured one, and the stated range ends below it.
By their numbers in this assay, from the lowest: compounds 2 and 1 (each within the scatter of the next); then compound 3; then compound 4.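

In this assay the tail change on the acid-bearing analogue runs toward weaker inhibition (a 3.0-fold higher number from compound 3 to compound 4 (0.48 log units; beyond the scatter)), so with this head group, phenyl in place of phenoxymethyl on an aromatic carbon does not by itself bring the low numbers of compound 1 and compound 2. Within the data shown here, with the phenyl tail held constant, the head group proves to matter far more than the one earlier step suggested, both for 5-carboxypyridin-2-yl in place of 6-(methoxycarbonyl)pyridin-3-yl (a 23-fold higher number from compound 2 to compound 4 (1.37 log units; beyond the scatter)) and for 5-carboxypyridin-2-yl in place of 6-carbamoylpyridin-2-yl (a 12-fold higher number from compound 1 to compound 4 (1.07 log units; beyond the scatter)). Nothing at hand accounts for the size or direction of any of these steps.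

The compounds shown leave open whether the tail step would keep its direction on a head group carrying a methyl ester or a primary amide, since the phenoxymethyl tail appears here only with the carboxylic acid. They also leave open how much of the head-group steps belongs to the carboxylic acid itself and how much to where it sits on the pyridine, a question that 5-(methoxycarbonyl)pyridin-2-yl on the phenyl tail would bear on directly.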